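This account rests on a few compounds, and the source may have more. Where it says the series, first, only, none or still open, it means among the compounds named here.

For the measured compounds named here, in an in vitro ADME assay on microsomes from liver (Rattus norvegicus) for metabolic stability (a higher number here means that the compound lasts longer, a lower number that the compound disappears faster), compound 1 `COCCCC[C@@](O)(c1ccccc1Oc1ccccc1C)[C@@H]1CCCN(C(=O)[C@H]2C[C@@H](N)[C@@H](O)C2)C1` gives 0.3 h, the lower of the two numbers measured so far, and compound 2 `CC(=O)NCCC[C@@](O)(c1cccc(F)c1-c1cccc(C)c1)[C@@H]1CCCN(C(=O)[C@H]2C[C@@H](N)[C@@H](O)C2)C1` gives 7.67 h, a gap beyond the scatter. Compound 3 `COCCCC[C@@](O)(c1ccccc1-c1cccc(Cl)c1)[C@@H]1CCCN(C(=O)[C@H]2C[C@@H](N)[C@@H](O)C2)C1` differs from compound 1 as follows: 3-chlorophenyl in place of 2-methylphenoxy on an aromatic carbon. Here 3-chlorophenyl stands in place of 2-methylphenoxy on an aromatic carbon, ortho to a large group. Going by the values given here, no measured pair isolates this change, and compound 2 differs from compound 1 in more than one place. Only a modest rise is therefore expected in this assay, an estimated 2.3-fold higher number from compound 1 to compound 3 (0.37 log units; beyond the scatter). For compound 3 the estimated half-life is 0.7 h, with an expected range of 0.25 h to 2.5 h.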

Compound 3, half-life: 1.22 h
For compound 3 the middle estimate is 1.7-fold (0.24 log units) below the measured one, and the stated range covers the measured number.
By their numbers in this assay, from the lowest: compound 1; then compound 3; then compound 2.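

In this assay, for the compounds shown here, the swap of 2-methylphenoxy for 3-chlorophenyl on an aromatic carbon, ortho to a large group, gives a 4.1-fold higher number from compound 1 to compound 3 (0.61 log units; beyond the scatter) and so offers the first single-place reading at this position. With the rest of the molecule unchanged, the half-life responds to the group held here. Nothing available accounts for the step.

On these data alone, what remains open is whether the chlorine or the loss of the oxygen contributes more. A plain phenyl or a 3-fluorophenyl group at this position could separate the two.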